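This account rests on a few compounds, and the source may have more. Where it says the series, first, only, none or still open, it means among the compounds named here.

Compound 1 `CCCC/C=C/c1ccc(CO[C@@H]2CN[C@@H](CO)C2)cc1` and compound 2 `CCCCCC/C=C/c1ccc(CO[C@@H]2CN[C@@H](CO)C2)cc1` share one core and differ in a single place: ethyl in place of hydrogen on a saturated chain carbon, four bonds along the chain from a double-bonded chain carbon. In a functional assay on FL5.12 cells (Mus musculus) for cytotoxicity, read by flow cytometry, with a stated time of 48 h (on this read-out higher numbers stand for weaker inhibition and lower numbers for stronger inhibition), compound 1 gives 5500 nM, while compound 2 gives 1400 nM, a step of a 3.9-fold lower number from compound 1 to compound 2 (0.59 log units; beyond the scatter). Compound 3 `CCCCCCCCCCCCc1ccc(CO[C@@H]2CN[C@@H](CO)C2)cc1` carries a different chain; how its core differs from the core of compound 1 is not broken down here. In this assay compound 3 gives 10100 nM, the highest of the three numbers. Compound 4 `CCCCCCCCCCCCCCc1ccc(CO[C@@H]2CN[C@@H](CO)C2)cc1` has not yet been measured. It differs from compound 3 by the same kind of change: ethyl in place of hydrogen on a saturated chain carbon, ten or more bonds along the chain from an aromatic carbon, though the place of the change is not the same as between compound 1 and compound 2. The expected step, a 1.7-fold lower number from compound 3 to compound 4 (0.23 log units; within the scatter), rests on a 3.9-fold lower number from compound 1 to compound 2 (0.59 log units; beyond the scatter), tempered since the surroundings differ. Compound 4 is therefore expected to give about 6000 nM, likely between 2000 nM and 18000 nM.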

Compound 4, half-maximal inhibitory concentration: 10500 nM
Estimate against measurement, compound 4: 1.8-fold (0.24 log units) below; the measured number falls inside the stated range.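

Adding ethyl to the chain of compound 3 gives a 1.0-fold higher number from compound 3 to compound 4 (0.02 log units; within the scatter) in this assay and thus no readable change. The same change therefore does not carry over with the same size from the core of compound 1 to the core of compound 3: the same change on two cores in this assay, a 3.9-fold lower number (0.59 log units; beyond the scatter) from compound 1 to compound 2 and a 1.0-fold higher number (0.02 log units; within the scatter) from compound 3 to compound 4, 4.1-fold (0.61 log units) apart, beyond the scatter of two such steps. Among the compounds shown here, this comparison rests on only two steps, with the change at a different place on each chain, so it does not show which difference between the two pairs matters, or what the step would be on any other chain.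

The compounds shown leave open how a longer chain, or a chain ending in an amine or a carboxylic acid, would read in this assay on the shared core.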